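Trisubstituted aryl methoxy addition in pyrazole chalcone series

The compounds below may be only part of what the source reports. "The series", "measured", "known", "first", "only" and "open" are said of these compounds alone.

Compound 1 `COc1ccc(-c2cc(/C=C/C(=O)c3ccc(N)cc3)[nH]n2)cc1` gives 18000 nM in a functional assay on SK-OV-3 cells (Homo sapiens) for inhibition, read by sulforhodamine B assay, with a stated time of 48 h; on this read-out lower numbers stand for stronger inhibition of growth and higher numbers for weaker inhibition of growth. Compound 3 `COc1ccc(-c2cc(/C=C/C(=O)c3ccc(N)cc3)[nH]n2)cc1OC` differs from it by methoxy in place of hydrogen on an aromatic carbon and gives 16800 nM in this assay, so the step of a 1.1-fold lower number from compound 1 to compound 3 (0.03 log units; within the scatter). Compound 2 `COc1ccc(C(=O)/C=C/c2cc(-c3cc(OC)c(OC)c(OC)c3)n[nH]2)cc1OC` has a core whose difference from that of compound 1 is not broken down here; compound 2 gives 7820 nM in this assay, the lowest of the three numbers. Compound 4 `COc1cc(C(=O)/C=C/c2cc(-c3cc(OC)c(OC)c(OC)c3)n[nH]2)cc(OC)c1OC` is not yet measured; it differs from compound 2 by methoxy in place of hydrogen on an aromatic carbon. This is the same kind of change as that from compound 1 to compound 3, but the place is not identical: in compound 4 the site is also meta to a methoxy group. Resting on the step from compound 1 to compound 3, the expected step is a 1.1-fold lower number from compound 2 to compound 4 (0.05 log units; within the scatter). Compound 4 is therefore estimated at 7000 nM in this assay, within 3500 nM to 14000 nM.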

Compound 4, concentration for total growth inhibition: 11100 nM
Compound 4: the middle estimate sits 1.6-fold (0.20 log units) below what was measured; the range from low to high includes it.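

In this assay methoxy in place of hydrogen on an aromatic carbon gives a 1.4-fold higher number from compound 2 to compound 4 (0.15 log units; within the scatter) and this step can be set against the earlier one on the other core: the same change on two cores in this assay, a 1.1-fold lower number (0.03 log units; within the scatter) from compound 1 to compound 3 and a 1.4-fold higher number (0.15 log units; within the scatter) from compound 2 to compound 4, 1.5-fold (0.18 log units) apart, within the scatter of two such steps.

On these two cores, then, the change leaves the number within the scatter, and the two steps agree within the scatter. Two pairs do not show that this carries over to further cores, and the site of the change is not identical in the two pairs.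

Open, as far as these compounds go, is whether a different group at this site, such as a carboxylic acid or an ethoxy group, would move the number beyond the scatter on either core.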